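Estimating compound 3 from one measured step

The source may hold more compounds than are shown below. What is called first, only, known or untested is meant among the compounds shown, and "the series" means these compounds.

Compound 1 `CC(=O)n1nc(NC(=O)c2ccccc2)c2c1CN(C(=O)c1ccccc1)C2` at 580 nM
Compound 2 `CC(=O)n1nc(NC(=O)c2ccccc2)c2c1CN(C(=O)CCl)C2` at 4100 nM

In a functional assay on HCT-116 cells (Homo sapiens) for cytotoxicity, read by sulforhodamine B assay, with a stated time of 48 h (on this read-out higher numbers stand for weaker inhibition and lower numbers for stronger inhibition), compound 2 gives 4100 nM and compound 1 gives 580 nM so compound 2 is the weaker of the two measured compounds. The unmeasured compound 3 `CC(=O)n1nc(NC(=O)c2ccccc2)c2c1CN(C(=O)N(C)C)C2` keeps the shared core of compound 2 and has dimethylamino in place of chloromethyl on a carbonyl carbon. The full count of that change is dimethylamino in place of chloromethyl on a carbonyl carbon and it is the next point to test.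

Among the compounds with values here, only one measured step bears on it (a 7.1-fold higher number from compound 1 to compound 2 (0.85 log units; beyond the scatter)), and that modest step was made on the same carbonyl carbon. It shows that a change there can move the number beyond the usual scatter. It cannot show how dimethylamino will behave, since neither measured compound carries that group. No direction can be argued from the data, so the best expectation is no step beyond the scatter, although a modest step either way remains possible. The expected change is a 1.0-fold lower number from compound 2 to compound 3 (0.01 log units; within the scatter) in this estimate. Compound 3 is expected at 4000 nM with 1100 nM to 14000 nM as its likely range.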

Compound 3, half-maximal inhibitory concentration: 70300 nM
Compound 3: middle estimate off by 18-fold (1.24 log units), on the low side, outside the stated range (above it).
By their numbers in this assay, from the lowest: compound 1; then compound 2; then compound 3.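

In this assay, the group on this carbonyl carbon matters more than the first pair could show: putting dimethylamino in place of chloromethyl gives a 17-fold higher number from compound 2 to compound 3 (1.23 log units; beyond the scatter) and is a large step, whereas the earlier change from phenyl to chloromethyl gave a 7.1-fold higher number from compound 1 to compound 2 (0.85 log units; beyond the scatter) and was only modest. Setting dimethylamino against phenyl widens the gap further, with a 120-fold higher number from compound 1 to compound 3 (2.08 log units; beyond the scatter) as the largest step in the set, and since every step among the three lies beyond the scatter, the groups fall into a clear order, with phenyl giving the strongest inhibition, chloromethyl the middle and dimethylamino the weakest. The swap itself looks small on paper, with 2 heavy atoms leaving and 3 entering, and no measurement at hand explains why the number moves so far.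

Within the data shown here, with only three groups on this carbon, it stays open whether the loss goes with any amine attached to the carbonyl or with dimethylamino in particular. A ring amine such as morpholine, a plain methyl or a longer alkyl chain at this place would help separate those readings, and whether the same order holds when the rest of the shared core changes is also unknown.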